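This account rests on a few compounds, and the source may have more. Where it says the series, first, only, none or still open, it means among the compounds named here.

Measured compounds in an assay on isolated protein for inhibition of histone deacetylase 5 (Homo sapiens), tested at 1 uM; a higher number here means more inhibition at the concentration tested (going by the name of the read-out), a lower number less inhibition:
- compound 1 `CC(C)(C(=O)Nc1ccc(C(=O)Nc2ccc(F)cc2N)cc1)c1ccccc1`: 0%
- compound 2 `CC(C)[C@@H](C(=O)Nc1ccc(C(=O)Nc2ccc(F)cc2N)cc1)c1ccccc1`: 0%

Compound 2 stands level with compound 1 at the digits shown; the only measured step, no change at the digits printed from compound 1 to compound 2 (within the scatter), is within the scatter. Compound 3 `Nc1cc(F)ccc1NC(=O)c1ccc(NC(=O)C2CC2c2ccccc2)cc1` is not yet measured. It differs from compound 2 as follows: 2-phenylcyclopropyl in place of 2-methyl-1-phenylpropyl on a carbonyl carbon. Among the measured compounds shown here, only the step from compound 1 to compound 2 bears on this change, and it showed nothing beyond the scatter, so no step beyond the scatter is expected here either, a number 2 percentage points higher from compound 2 to compound 3 (within the scatter). For compound 3 the estimate is 2%, with a range from 0% to 15%.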

Compound 3, a percentage reported as inhibition, at one concentration (the size of the read-out at that concentration, not a potency): 3%
The estimate for compound 3 lay 1 percentage points below the measured number; the measured number falls inside the stated range.
By their numbers in this assay, from the lowest: compounds 1, 2 and 3 (each within the scatter of the next).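

In this assay a three-membered ring on the carbonyl carbon, as 2-phenylcyclopropyl, gives no separation from the open branched groups: the replacement of 2-methyl-1-phenylpropyl gives a number 3 percentage points higher from compound 2 to compound 3 (within the scatter) and the replacement of 1-methyl-1-phenylethyl gives a number 3 percentage points higher from compound 1 to compound 3 (within the scatter) at this position. All three phenyl-bearing groups therefore read alike, now including a ring-closed one. No supporting data bear on this result.

Open, as far as these compounds go, is whether a group of another type here, such as an amine or a carboxylic acid, would separate from these three in this assay at all.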